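A few compounds are considered here, and "the series" means these few. Any claim that something is new, unique, unknown or untested is made for them only; others in the source may bear on it.

Of the compounds shown here, three built on a shared core have been measured in a functional assay on HGC-27 cells (Homo sapiens) for inhibition, read by MTT assay, with a stated time of 72 h; a higher number here means a weaker inhibitor, a lower number a stronger inhibitor. Compound 1 `Cc1cc(N2CC[C@@H](C)[C@@H](N(C)c3ncnc4[nH]ccc34)C2)n2nc(SCC3CC3)nc2n1` gives 21400 nM. Compound 2 `Cc1cc(N2CC[C@@H](C)[C@@H](N(C)c3ncnc4[nH]ccc34)C2)n2nc(SCc3ccc(F)cc3)nc2n1` gives 26000 nM, and compound 3 `COc1ccc(CSc2nc3nc(C)cc(N4CC[C@@H](C)[C@@H](N(C)c5ncnc6[nH]ccc56)C4)n3n2)cc1` gives 18200 nM. Compound 1 stands second highest of these three numbers; compound 3 is nearest to it and compound 2 furthest, and both of those gaps lie within the scatter.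

Compound 4 `Cc1cc(N2CC[C@@H](C)[C@@H](N(C)c3ncnc4[nH]ccc34)C2)n2nc(SCc3ccc(Br)cc3)nc2n1` has not yet been measured. It differs from compound 1 in one place: 4-bromophenyl in place of cyclopropyl on a saturated chain carbon bound to a sulfur

Within the data shown here, two measured steps bear on this change, since each also puts an aromatic ring in place of cyclopropyl on a saturated chain carbon bound to a sulfur: a 1.2-fold higher number from compound 1 to compound 2 (0.08 log units; within the scatter) and a 1.2-fold lower number from compound 1 to compound 3 (0.07 log units; within the scatter). A third step, a 1.4-fold lower number from compound 2 to compound 3 (0.15 log units; within the scatter), exchanges one substituent on that aromatic ring for another. None of these three steps moved the number beyond the scatter. The step expected in this assay is accordingly a 1.0-fold lower number from compound 1 to compound 4 (0.01 log units; within the scatter). Compound 4 is estimated to give about 21000 nM, between 9000 nM and 50000 nM.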

Compound 4, half-maximal inhibitory concentration: 19500 nM
The estimate for compound 4 lay 1.1-fold (0.03 log units) above the measured number; low and high end bracket the measured number.
By their numbers in this assay, from the lowest: compounds 3, 4, 1 and 2 (each within the scatter of the next).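

In this assay, the larger 4-bromophenyl group, with 7 heavy atoms against the 3 of cyclopropyl, gives a 1.1-fold lower number from compound 1 to compound 4 (0.04 log units; within the scatter), so a halogen heavier than fluoro still produces no step beyond the scatter at this position. The ring substituent shows the same picture, with a 1.1-fold higher number from compound 3 to compound 4 (0.03 log units; within the scatter) for bromo in place of methoxy and a 1.3-fold lower number from compound 2 to compound 4 (0.12 log units; within the scatter) for bromo in place of fluoro. Compound 1, compound 2, compound 3 and compound 4 thus all lie within the scatter of one another, and nothing measured here accounts for this sameness.

On these data alone, whether any group at this position can move the number beyond the scatter stays open. An amine or a carboxylic acid on the aromatic ring, or a longer chain in place of cyclopropylmethyl, would be a direct test.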